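Chain extension on two stereoisomeric aminofuranose cores

This account rests on a few compounds, and the source may have more. Where it says the series, first, only, none or still open, it means among the compounds named here.

Measured compounds:
compound 1 `CCCCCCCCNC[C@@H]1OC[C@H](N)[C@@H]1O`: 13800 nM
compound 2 `CCCCCCCCCCCCNC[C@@H]1OC[C@H](N)[C@@H]1O`: 850 nM
compound 3 `CCCCCCCNC[C@@H]1OC[C@H](N)[C@H]1O`: > 128000 nM

In a functional assay on PC-3 cells (Homo sapiens) for antiproliferative activity, read by MTT assay, with a stated time of 72 h (a lower number here means a stronger inhibitor, a higher number a weaker inhibitor), compound 1 gives 13800 nM and compound 2 gives 850 nM. The step is a 16-fold lower number from compound 1 to compound 2 (1.21 log units; beyond the scatter); the change is butyl in place of hydrogen on a saturated chain carbon, eight bonds along the chain from an amine nitrogen. For compound 3 this assay reports only a limit, > 128000 nM, which is the limit of > 128000 nM in this assay, at which 1 of the 3 values shown sits. The difference between the core of compound 1 and the core of compound 3 is not broken down here.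

Compound 4 `CCCCCCCCCCCNC[C@@H]1OC[C@H](N)[C@H]1O` has not been measured in this assay. It arises from compound 3 by butyl in place of hydrogen on a saturated chain carbon, seven bonds along the chain from an amine nitrogen. This is the same kind of change as that from compound 1 to compound 2, although there the butyl enters eight bonds along the chain from the amine nitrogen, and here seven bonds along the chain from the amine nitrogen. A step of a size comparable to a 16-fold lower number from compound 1 to compound 2 (1.21 log units; beyond the scatter) is expected, an at least 8.0-fold lower number from compound 3 to compound 4 (0.90 log units; beyond the scatter), resting only on that one measured pair. Because compound 3 shows only > 128000 nM, the starting point is uncertain and the result for compound 4 may again be a limit. Compound 4 is estimated at 16000 nM.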

Compound 4, half-maximal inhibitory concentration: 10000 nM
Compound 4: the middle estimate sits 1.6-fold (0.20 log units) above what was measured; measured number inside the range.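

In this assay, butyl in place of hydrogen on a saturated chain carbon, seven bonds along the chain from an amine nitrogen, gives an at least 12-fold lower number from compound 3 to compound 4 (1.10 log units; beyond the scatter), so the change keeps its direction on the second core. This rests on one pair on each of two cores, so it sets no rule beyond them, and whether the step has the same size on both stays unsettled: the same change on two cores in this assay, a 16-fold lower number (1.21 log units; beyond the scatter) from compound 1 to compound 2 and an at least 12-fold lower number (1.10 log units; beyond the scatter) from compound 3 to compound 4; the limit leaves it open whether they differ The value of compound 3, > 128000 nM, is a limit of the assay and not a number: the limit of > 128000 nM in this assay, at which 1 of the 4 values shown sits.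

The effect of the core alone, with one and the same chain on both cores, stays open in the compounds shown. Also open, as far as these compounds go, is how a longer chain, or an amide in place of the chain amine, would read on either core in this assay.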